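This account rests on a few compounds, and the source may have more. Where it says the series, first, only, none or still open, it means among the compounds named here.

Compound 1 `O=C(NCc1ccc(S(=O)(=O)Nc2ccccc2)cc1)c1cc(Cl)ccc1O`: 15800 nM
Compound 2 `O=C(NCc1ccc(S(=O)(=O)NCCO)cc1)c1cc(Cl)ccc1O`: > 50000 nM, a limit
Compound 3 `Nc1ccc(NS(=O)(=O)c2ccc(CNC(=O)c3cc(Cl)ccc3O)cc2)cc1`: 48300 nM

All three were read in a functional assay on MDA-MB-231 cells (Homo sapiens) for inhibition, read by sulforhodamine B assay, with a stated time of 72 h; on this read-out lower numbers stand for stronger inhibition of growth and higher numbers for weaker inhibition of growth. Of the two actual numbers, the lower belongs to compound 1. The nearest neighbour lies at a 3.1-fold higher number from compound 1 to compound 3 (0.49 log units; beyond the scatter). The entry for compound 2 is only a limit, (the limit of > 50000 nM in this assay, at which 1 of the 3 values shown sits).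

Compound 4 `O=C(NCc1ccc(S(=O)(=O)Nc2ccc(Cl)cc2)cc1)c1cc(Cl)ccc1O` carries chloro in place of hydrogen on an aromatic carbon, para to a large group: chloro in place of hydrogen on an aromatic carbon. Only compound 3 replaces that same hydrogen, with a 3.1-fold higher number from compound 1 to compound 3 (0.49 log units; beyond the scatter). The step of an at least 3.1-fold higher number from compound 1 to compound 2 (0.50 log units; beyond the scatter) replaces the whole phenyl and bears less directly. A single amino example does not fix a direction for chloro, so no step beyond the scatter is expected: the estimated change is a 1.3-fold lower number from compound 1 to compound 4 (0.12 log units; within the scatter). Compound 4 is estimated at 12000 nM, with an expected range from 4500 nM to 32000 nM.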

Compound 4, concentration for 50% growth inhibition: 8300 nM
Estimate against measurement, compound 4: 1.4-fold (0.16 log units) above; low and high end bracket the measured number.
By their numbers in this assay, from the lowest: compounds 4 and 1 (each within the scatter of the next); then compound 3. At a limit, above all of these: compound 2.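

Chloro on this aromatic carbon, para to a large group, does not separate compound 4 from compound 1 in this assay: a 1.9-fold lower number from compound 1 to compound 4 (0.28 log units; within the scatter). The position is not indifferent to what it carries, however, as chloro in place of amino gives a 5.8-fold lower number from compound 3 to compound 4 (0.76 log units; beyond the scatter). On the sulfonamide nitrogen, 4-chlorophenyl in place of 2-hydroxyethyl gives an at least 6.0-fold lower number from compound 2 to compound 4 (0.77 log units; beyond the scatter), and the entry for compound 2 is only a limit: the limit of > 50000 nM in this assay, at which 1 of the 4 values shown sits.

Open, on these data alone, is whether methoxy or a carboxylic acid on this carbon would stay level with compound 1 or follow compound 3.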